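Sulfur for Oxygen in the Azole of Compound 1

The source may report more compounds than this note shows. Statements on the series, on what has been measured and on what is new or still open speak of the compounds shown alone.

Of the compounds shown here, three of this set have been tested for cytotoxicity in a functional assay on LM7 cells (Homo sapiens) for cytotoxicity, read by MTT assay, with a stated time of 72 h; on this read-out higher numbers stand for weaker inhibition and lower numbers for stronger inhibition. Compound 1 `Cc1nnc(SCc2cc(=O)c3ccccc3o2)o1` stands at a limit of the assay: in this assay compound 1 gives > 25000 nM, so no number is known for it. Compound 3 `Cc1ccc2oc(CSc3nnc(N)s3)cc(=O)c2c1` likewise gives only a limit, > 25000 nM. The single numerical result belongs to compound 2 `Cc1cc(C)n2nc(SCc3nnc(SCc4coc5ccccc5c4=O)n3N)nc2n1`, which in this assay gives 1900 nM. Compound 1 therefore shares (the limit of > 25000 nM in this assay, at which 2 of the 3 values shown sit), and sits clearly weaker than compound 2.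

The untested compound 4 `Cc1nnc(SCc2cc(=O)c3ccccc3o2)s1` differs from compound 1 in one place: 5-methyl-1,3,4-thiadiazol-2-yl in place of 5-methyl-1,3,4-oxadiazol-2-yl on a sulfur. Within the data shown here, no pair of tested compounds differs by this same change, so the size of the step has to be estimated without a precedent. Since compound 1 itself is at the limit, a step from it can only be resolved if compound 4 turns out stronger. The step that the limit leaves unreadable from compound 1 to compound 4 is expected to stay within the scatter. Compound 4 is accordingly estimated at 30000 nM, in a range from 8000 nM to 100000 nM, and most likely to be reported as a limit again.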

Compound 4, half-maximal inhibitory concentration: > 25000 nM
Compound 4 gave a limit, no number (the forecaster's own chance of this, stated with the estimate: 70%); the middle value is on the limit's open side.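

No step can be read between compound 1 and compound 4, since each gives only a limit of the assay: the limit of > 25000 nM in this assay, at which 3 of the 4 values shown sit.

The compounds shown leave open whether 5-methyl-1,3,4-thiadiazol-2-yl in place of 5-methyl-1,3,4-oxadiazol-2-yl on a sulfur changes the result at all in this assay.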